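The compounds below may be only part of what the source reports. "The series", "measured", "known", "first", "only" and "open" are said of these compounds alone.

Measured compounds:
compound 1, `CCCOP(=O)(O)OCCSC(=S)N1CCCCC1`, > 100000 nM
compound 2, `CCCCCCOP(=O)(O)OCCSC(=S)N1CCCCCC1`, 77400 nM
compound 3, `CCCCCCOP(=O)(O)OCCSC(=S)N1CCCCC1`, > 100000 nM

All three compounds were tested in a functional assay on DU-145 cells (Homo sapiens) for inhibition, read by MTT assay, with stated times of 18 h and 4 h; on this read-out higher numbers stand for weaker inhibition and lower numbers for stronger inhibition. Only compound 2 gives a number in this assay, namely 77400 nM. For compound 1 the result > 100000 nM is a limit of the assay, not a number. For compound 3 the result > 100000 nM is likewise a limit. Two of the three results therefore sit at the limit of > 100000 nM in this assay, at which 2 of the 3 values shown sit.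

Compound 3 and compound 2 share the same ester chain and differ only in the ring on the thiocarbonyl carbon: azepan-1-yl in place of piperidin-1-yl on a thiocarbonyl carbon. The step from one to the other reads an at least 1.2-fold higher number from compound 2 to compound 3 (0.11 log units; that floor lies within the scatter).

Compound 3 and compound 1 share the ring and differ in the ester chain: hydrogen in place of propyl on a saturated chain carbon, three bonds along the chain from an oxygen on an unsaturated carbon. Because both results are limits (the limit of > 100000 nM in this assay, at which 2 of the 3 values shown sit), this step is a step that the two limits leave unreadable from compound 3 to compound 1.

Compound 4, `CCCOP(=O)(O)OCCSC(=S)N1CCCCCC1`, has not yet been measured. It differs from compound 2 by hydrogen in place of propyl on a saturated chain carbon, three bonds along the chain from an oxygen on an unsaturated carbon, the same change as from compound 3 to compound 1. That earlier step gives no readable size, so the expectation rests on compound 2 alone, whose value is 77400 nM. Beside the earlier unreadable step, the step from compound 2 to compound 4 is expected to be a 1.9-fold higher number from compound 2 to compound 4 (0.29 log units; within the scatter). Compound 4 is expected to give about 150000 nM in this assay, with a wide range from 60000 nM to 400000 nM, and a fair chance that only a limit is reported.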

Compound 4, half-maximal inhibitory concentration: 86100 nM
The estimate for compound 4 lay 1.7-fold (0.24 log units) above the measured number; measured number inside the range.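

With the azepan-1-yl ring on the thiocarbonyl carbon, replacing hexyl by propyl in this assay gives a 1.1-fold higher number from compound 2 to compound 4 (0.05 log units; within the scatter), so this pair shows no difference that can be separated from the ordinary spread of repeated measurements. That does not show that the chain has no influence in general, only that no influence can be seen between these two compounds on this one core. The same change on the core with the piperidin-1-yl ring cannot be read, and so this pair can neither support nor contradict the result from compound 2 and compound 4, because compound 1 and compound 3 both give a limit rather than a number: the limit of > 100000 nM in this assay, at which 2 of the 4 values shown sit.

The compounds shown leave open how a chain longer than hexyl, such as octyl, or a chain ending in an amine or a carboxylic acid, would read in this assay. Among these compounds, the one readable step for this change stays within the scatter, so it also remains open whether any change to this chain can shift the read-out by more than that.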